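Selenium-Bearing Benzyl Group on a Shared Amidine Core

The compounds below may be only part of what the source reports. "The series", "measured", "known", "first", "only" and "open" are said of these compounds alone.

Measured so far:
compound 1, `CS/C(=N\C(=O)c1cc2ccccc2s1)NC(=O)c1cc2ccccc2s1`, 9510 nM
compound 2, `O=C(/N=C(/NC(=O)c1cc(-c2ccccc2)nc2ccccc12)[Se]Cc1ccccc1)c1cc(-c2ccccc2)nc2ccccc12`, 8460 nM
compound 3, `CS/C(=N\C(=O)c1cc(-c2ccccc2)nc2ccccc12)NC(=O)c1cc(-c2ccccc2)nc2ccccc12`, 43100 nM

All three compounds were tested in a functional assay on MCF7 cells (Homo sapiens) for cytotoxicity, read by MTT assay, with a stated time of 72 h; a higher number here means a weaker inhibitor of growth, a lower number a stronger inhibitor of growth. Compound 2 and compound 3 share one core and differ in a single place: a group of 8 heavy atoms (7 carbon, 1 selenium; one six-membered aromatic ring of carbon only) in place of a group of 2 heavy atoms (1 carbon, 1 sulfur; no ring), on a carbon with a double bond to nitrogen. That change produced a 5.1-fold lower number from compound 3 to compound 2 (0.71 log units; beyond the scatter). Compound 1 carries a different core, and the difference between the two cores is not broken down here. Compound 1 sits close to compound 2 in this assay, while its number is well apart from that of compound 3.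

Compound 4, `O=C(/N=C(/NC(=O)c1cc2ccccc2s1)[Se]Cc1ccccc1)c1cc2ccccc2s1`, has not yet been measured in this assay. It is related to compound 1 by the same change that separates compound 3 from compound 2: a group of 8 heavy atoms (7 carbon, 1 selenium; one six-membered aromatic ring of carbon only) in place of a group of 2 heavy atoms (1 carbon, 1 sulfur; no ring), on a carbon with a double bond to nitrogen. The surroundings of the change are the same in both pairs, so it is the same change on a different core.

Whether the change will act on the core of compound 1 as it did on the core of compound 3 is not shown by the data; only one example of the change is available. Because compound 3 gave 43100 nM and compound 2 gave 8460 nM, a step of similar direction is expected, though compound 1 already starts at 9510 nM, so a smaller step seems plausible. Compound 4 is therefore estimated at 3000 nM, between 1000 nM and 9000 nM, which means an expected step of a 3.2-fold lower number from compound 1 to compound 4 (0.50 log units; beyond the scatter).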

Compound 4, concentration for 50% growth inhibition: 37900 nM
Estimate against measurement, compound 4: 13-fold (1.10 log units) below; the measured number lies above the stated range.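

In this assay, putting the selenium-bearing group in place of methylsulfanyl on the core of compound 1 gave a 4.0-fold higher number from compound 1 to compound 4 (0.60 log units; beyond the scatter), so on this core the change weakened growth inhibition rather than strengthening it. The change therefore cannot be carried from one core to the other in this series with its effect assumed to stay the same, as the two pairs moved in opposite directions: the same change on two cores in this assay, a 5.1-fold lower number (0.71 log units; beyond the scatter) from compound 3 to compound 2 and a 4.0-fold higher number (0.60 log units; beyond the scatter) from compound 1 to compound 4, 20-fold (1.31 log units) apart, beyond the scatter of two such steps. Among the compounds shown here, this shows that the result of the change depends on the core that carries it, but with only two pairs it does not show which feature of the cores is responsible, or what the change would do on a third core.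

The change swaps the selenium atom and the benzene ring in together, so the compounds shown leave open which of them matters on each core; a benzylsulfanyl group or a methylselanyl group on the same carbon with a double bond to nitrogen would separate the two. Also open, going by these compounds, is how a simple amine or a longer alkyl chain at that place would behave on either core, and whether the opposite directions hold in cell lines other than this one.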